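The source may report more compounds than this note shows. Statements on the series, on what has been measured and on what is new or still open speak of the compounds shown alone.

Values in a functional assay on NCI-H520 cells (Homo sapiens) for cytotoxicity; on this read-out higher numbers stand for weaker inhibition of growth and lower numbers for stronger inhibition of growth:
- compound 1 `COc1ccc(C2=C(c3ccc(SC)cc3)CC3CCCN3C2=O)cc1Br`: 700 nM
- compound 2 `COc1ccc(C2=C(c3ccc(SC)cc3)CC3CCCN3C2=O)cc1C`: 100 nM
- compound 3 `COc1ccc(C2=C(c3ccc(SC)cc3)CC3CCCN3C2=O)cc1`: 800 nM

Compound 3 sits at the high end of these numbers, together with compound 1, and well above compound 2. The two steps that place it are a 1.1-fold higher number from compound 1 to compound 3 (0.06 log units; within the scatter) and an 8.0-fold higher number from compound 2 to compound 3 (0.90 log units; beyond the scatter).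

The next compound is compound 4 `CSc1ccc(C2=C(c3ccc(F)cc3)C(=O)N3CCCC3C2)cc1`, which replaces the methoxy of compound 3: fluoro in place of methoxy on an aromatic carbon. In words, this is 4-methoxyphenyl to 4-fluorophenyl.

Within the data shown here, no measured step touches this position, since all three measured compounds carry the methoxy. The nearest evidence comes from changes at another aromatic carbon of the same ring. There, a 7.0-fold lower number from compound 1 to compound 2 (0.85 log units; beyond the scatter) and an 8.0-fold higher number from compound 2 to compound 3 (0.90 log units; beyond the scatter) were modest, while a 1.1-fold higher number from compound 1 to compound 3 (0.06 log units; within the scatter) stayed within the scatter. These steps show that single replacements on this ring can either leave this assay unchanged or shift it modestly, but they give no direction for the new change.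

Losing a methoxy that is common to the whole set is therefore judged, tentatively, to weaken growth inhibition modestly. The expected step is a 2.5-fold higher number from compound 3 to compound 4 (0.40 log units; beyond the scatter). For compound 4 the estimated value is 2000 nM, with an expected range of 500 nM to 10000 nM.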

Compound 4, concentration for 50% growth inhibition: 250 nM
Beside the measured number, compound 4's estimate is 8.0-fold (0.90 log units) above it, outside the stated range (below it).
By their numbers in this assay, from the lowest: compound 2; then compound 4; then compounds 1 and 3 (each within the scatter of the next).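

In this assay, among these compounds, the methoxy shared by compounds 1 to 3 proves dispensable: fluoro in place of methoxy on this aromatic carbon, para to a large group, gives a 3.2-fold lower number from compound 3 to compound 4 (0.51 log units; beyond the scatter), so this first reading at the position moves towards stronger inhibition of growth, against the loss of activity that might be assumed for a group common to the earlier compounds. Read as whole-aryl replacements, 4-fluorophenyl in place of 4-methoxy-3-methylphenyl gives a 2.5-fold higher number from compound 2 to compound 4 (0.40 log units; beyond the scatter), and 4-fluorophenyl in place of 3-bromo-4-methoxyphenyl gives a 2.8-fold lower number from compound 1 to compound 4 (0.45 log units; beyond the scatter), which places compound 4 between compound 2 and the pair of compounds 1 and 3. No available data bear on why fluoro and methoxy differ here.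

As far as these compounds go, it remains open whether the same change would carry over to the methyl-bearing ring of compound 2, as a 4-fluoro-3-methylphenyl group. Also open, from the compounds shown here alone, is how an amine, a hydroxyl or a chlorine would read at this position, and whether the methylthio group on the other aryl ring can be replaced.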